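Swapping an Ethylamino for a Dimethylamino Group

This account rests on a few compounds, and the source may have more. Where it says the series, first, only, none or still open, it means among the compounds named here.

Measured so far:
compound 1, `Clc1[nH]ccc2ncnc1-2`, gives < 5% in a functional assay on EL4 cells (Mus musculus) for inhibition, tested at 100 uM; on this read-out lower numbers stand for less inhibition and higher numbers for more inhibition at the one concentration tested (going by the name of the read-out).
compound 2, `CCNc1nccc2c1ncn2C1O[C@H](CO)[C@@H](O)[C@H]1O`, gives 8% in this assay.

The value for compound 1 is a limit of this assay, not a number. Within the data shown here, compound 2 is thus the only compound with a measured number, and that number is small; its nearest company is the limit of < 5% in this assay, at which 1 of the 2 values shown sits. Among the measured compounds shown here, no two measured compounds differ in a single place, so no measured step exists to lean on.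

Compound 3, `CN(C)c1nccc2c1ncn2C1O[C@H](CO)[C@@H](O)[C@H]1O`, has not yet been measured. It is built from the same atoms as compound 2, joined differently: dimethylamino in place of ethylamino on an aromatic carbon.

With compound 2 already near the bottom of the scale, the change is expected to bring no step beyond the usual scatter, a number 1 percentage points lower from compound 2 to compound 3 (within the scatter). Compound 3 is therefore estimated to give 7% in this assay, with a range from 0% to 18%.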

Compound 3, a percentage reported as inhibition, at one concentration (the size of the read-out at that concentration, not a potency): 10%
Compound 3: middle estimate off by 3 percentage points, on the low side; measured number inside the range.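

Moving from ethylamino to dimethylamino on this aromatic carbon, next to the ring nitrogen, gives a number 2 percentage points higher from compound 2 to compound 3 (within the scatter). The swap keeps the same atoms but takes away the hydrogen-bond donor of ethylamino, and in this assay this leaves no difference that can be told from scatter. The step offers only limited insight into this position, since both numbers lie at the low end of the scale, where there is little room to see a loss of inhibition: the limit of < 5% in this assay, at which 1 of the 3 values shown sits.

Going by these compounds, it remains open whether a larger change at this carbon, such as a plain amino group or a longer chain like butylamino, would lift inhibition clear of the scatter. Whether a carboxylic acid there would do so is equally unknown.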